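A few compounds are considered here, and "the series" means these few. Any claim that something is new, unique, unknown or untested is made for them only; others in the source may bear on it.

Compound 2 `COc1cc(NC(C)CCCN2C(=O)CN(C(C)=O)C2(C)C)c2ncccc2c1` is the member of the series that carries an acetyl on the ring nitrogen of the shared core. In an ADME assay on A549 cells (Homo sapiens) for cytotoxicity, with a stated time of 72 h (a higher number here means a weaker inhibitor, a lower number a stronger inhibitor), compound 2 returns only the limit of the assay, > 100000 nM, and not a number. Compound 1 `COc1cc(NC(C)CCCN2C(=O)[C@@H](C)N(C(=O)CN)C2(C)C)c2ncccc2c1` stands at the same point: in this assay compound 1 likewise gives only the limit > 100000 nM. For the measured compounds named here, both measured compounds thus share (the limit of > 100000 nM in this assay, at which 2 of the 2 values shown sit), and no step between two measured compounds can be read. Compound 3 `COc1cc(NC(C)CCCN2C(=O)CN(C(=O)CN)C2(C)C)c2ncccc2c1` carries amino in place of hydrogen on a saturated chain carbon bound to a carbonyl carbon. Compound 3 is therefore the acetyl to (aminomethyl)carbonyl change made on compound 2, a change compound 1 already carries together with its extra methyl while staying at the limit. No shift beyond the scatter is expected, and the step from compound 2 to compound 3 is estimated as a number no higher from compound 2 to compound 3 (the limit leaves the size open), that is, none. Compound 3 is expected at about 100000 nM, within 50000 nM to 300000 nM, most likely reported once more only as a limit.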

Compound 3, half-maximal inhibitory concentration: > 100000 nM
Compound 3: no number, only a limit; the forecaster's own chance of this, stated with the estimate: 85%; the middle value sits exactly at the limit.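

No step can be read from compound 2 or compound 1 to compound 3, because all three give only a limit and not a number: the limit of > 100000 nM in this assay, at which 3 of the 3 values shown sit.

The compounds shown leave open how compound 1, compound 2 and compound 3 truly compare in this assay, and whether any change on the shared core would give a measurable value.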